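Thioether chain variation on the shared core

The compounds below may be only part of what the source reports. "The series", "measured", "known", "first", "only" and "open" are said of these compounds alone.

Compound 1 `CCCCSc1n[nH]c(-n2[se]c3ccccc3c2=O)n1` carries a butylsulfanyl group on the shared core. In a functional assay on HeLa cells (Homo sapiens) for antiproliferative activity, read by CCK-8 assay, with a stated time of 48 h (on this read-out lower numbers stand for stronger inhibition and higher numbers for weaker inhibition), compound 1 gives 32900 nM, the lowest of the two numbers in hand. Compound 3 `O=c1c2ccccc2[se]n1-c1nc(SCc2ccc(Cl)cc2)n[nH]1` carries 4-chlorophenyl in place of propyl on a saturated chain carbon bound to a sulfur and gives 40900 nM. The step reads a 1.2-fold higher number from compound 1 to compound 3 (0.09 log units; within the scatter). Compound 2 `O=c1c2ccccc2[se]n1-c1nc(SCc2ccc(F)cc2)n[nH]1` carries 4-fluorophenyl in the same place and reaches only a limit of the assay, > 50000 nM. Accordingly an at least 1.5-fold higher number from compound 1 to compound 2 (0.18 log units; that floor lies within the scatter) and an at least 1.2-fold lower number from compound 2 to compound 3 (0.08 log units; that floor lies within the scatter) rest on that floor (the limit of > 50000 nM in this assay, at which 1 of the 3 values shown sits).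

Compound 4 `CC(C)Sc1n[nH]c(-n2[se]c3ccccc3c2=O)n1` has not yet been measured. It differs from compound 1 as follows: isopropyl in place of butyl on a sulfur. Among the measured compounds shown here, no measured pair changes the chain on the sulfur in this way; the two measured steps exchange propyl for an aryl group, and neither moves beyond the scatter or beyond the floor. Across these three compounds the thioether substituent leaves the read-out nearly unchanged, so no step beyond the scatter is expected from butyl to isopropyl in this assay; the expected step is a 1.1-fold higher number from compound 1 to compound 4 (0.03 log units; within the scatter). Compound 4 is therefore estimated to give 35000 nM in this assay, with a range from 15000 nM to 50000 nM.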

Compound 4, half-maximal inhibitory concentration: 34600 nM
Compound 4: the middle estimate sits 1.0-fold (0.00 log units) above what was measured; low and high end bracket the measured number.
By their numbers in this assay, from the lowest: compounds 1, 4 and 3 (each within the scatter of the next). At a limit, above all of these: compound 2.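

Working notes on the thioether position: isopropyl in place of butyl on a sulfur is the first exchange of one alkyl group for another here, and in this assay it gives a 1.1-fold higher number from compound 1 to compound 4 (0.02 log units; within the scatter). Against the aryl-bearing substituent, the series reads a 1.2-fold lower number from compound 3 to compound 4 (0.07 log units; within the scatter), so isopropylsulfanyl and the 4-chlorobenzyl thioether are not separated by this read-out, and the flat picture among compounds 1, 3 and 4 now covers butyl, isopropyl and 4-chlorobenzyl on the sulfur. Compound 2 stands at a limit of the assay, not at a number, so an at least 1.4-fold lower number from compound 2 to compound 4 (0.15 log units; that floor lies within the scatter) gives only a floor and does not show that compound 2 differs from compound 4: the limit of > 50000 nM in this assay, at which 1 of the 4 values shown sits.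

Every substituent shown on the sulfur is a short alkyl group or a halogenated benzyl group, so it remains open whether a terminal amine, a carboxylic acid or a longer chain such as decyl would move the read-out beyond the scatter. All four compounds keep the shared core unchanged, which leaves open what a sulfur atom in place of its selenium would do in this assay.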